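Methoxycarbonyl to nitro: compound 3 to compound 4

The compounds below may be only part of what the source reports. "The series", "measured", "known", "first", "only" and "open" are said of these compounds alone.

In a functional assay on SK-OV-3 cells (Homo sapiens) for inhibition, read by CCK-8 assay, with a stated time of 70 h (a higher number here means a weaker inhibitor, a lower number a stronger inhibitor), compound 1 (`c1ccc(COc2ccc(OCCOCCNC3CCCC3)cc2)cc1`) gives 24800 nM, compound 2 (`Nc1ccc(COc2ccc(OCCOCCNC3CCCC3)cc2)cc1`) gives 31700 nM and compound 3 (`COC(=O)c1ccc(COc2ccc(OCCOCCNC3CCCC3)cc2)cc1`) gives 6990 nM. Compound 3 holds the lowest number of the three, beyond the scatter from both others.

The next structure is compound 4 (`O=[N+]([O-])c1ccc(COc2ccc(OCCOCCNC3CCCC3)cc2)cc1`), with nitro in place of methoxycarbonyl on an aromatic carbon, para to a large group: nitro in place of methoxycarbonyl on an aromatic carbon.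

For the measured compounds named here, no measured compound carries nitro, so only steps at this same carbon bear on the change. The amino step, a 1.3-fold higher number from compound 1 to compound 2 (0.11 log units; within the scatter), stays within the scatter. The two steps that introduce methoxycarbonyl are modest: a 3.5-fold lower number from compound 1 to compound 3 (0.55 log units; beyond the scatter) and a 4.5-fold lower number from compound 2 to compound 3 (0.66 log units; beyond the scatter). The largest of these, a 4.5-fold lower number from compound 2 to compound 3 (0.66 log units; beyond the scatter), suggests an upper size for changes at this carbon, and the swap here is expected to be smaller.

The expected step is small and slightly upward, probably within the scatter: a 1.3-fold higher number from compound 3 to compound 4 (0.11 log units; within the scatter). For compound 4 the estimated value in this assay is 9000 nM, with an expected range of 3500 nM to 20000 nM.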

Compound 4, half-maximal inhibitory concentration: 20300 nM
Estimate against measurement, compound 4: 2.3-fold (0.35 log units) below, and the stated range ends below it.
By their numbers in this assay, from the lowest: compound 3; then compounds 4, 1 and 2 (each within the scatter of the next).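

In this assay the lower number of compound 3 does not carry over to nitro at this carbon, with a 2.9-fold higher number from compound 3 to compound 4 (0.46 log units; beyond the scatter) on the aromatic carbon para to a large group. Nitro stays within the scatter of both hydrogen and amino, giving a 1.2-fold lower number from compound 1 to compound 4 (0.09 log units; within the scatter) and a 1.6-fold lower number from compound 2 to compound 4 (0.19 log units; within the scatter), so among the four compounds only methoxycarbonyl stands apart from the rest, and the nitro result adds no sign of a trend across the other three groups. No available data accounts for the separation between methoxycarbonyl and nitro.

As far as these compounds go, whether the ester itself matters remains open, and the carboxylic acid, the primary amide and the ethyl ester at this carbon would test that. A nitrile or an acetyl group would show whether any other group shares the standing of methoxycarbonyl.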